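Sulfonamide variation on the shared core: towards compound 3

The compounds below may be only part of what the source reports. "The series", "measured", "known", "first", "only" and "open" are said of these compounds alone.

Measured so far, in a functional assay (plasma) for inhibition, with Oryctolagus cuniculus as the target; a lower number here means a stronger inhibitor, a higher number a weaker inhibitor:
compound 1, `Cc1ccccc1S(=O)(=O)N[C@H]1C2CC[C@H](C2)[C@@H]1C/C=C\CCCC(=O)O`: compound 1 gives 6200 nM
compound 2, `O=C(O)CCC/C=C\C[C@H]1[C@@H]2CCC(C2)[C@@H]1NS(=O)(=O)CCCc1ccccc1`: compound 2 gives 14000 nM

Within the data shown here, compound 1 holds the lowest of the two numbers in this assay; its nearest neighbour is compound 2, and the one measured step runs a 2.3-fold higher number from compound 1 to compound 2 (0.35 log units; beyond the scatter). Among the measured compounds shown here, that step exchanges the whole group on the sulfonyl sulfur for a chain, so it is the only guide on how this assay reacts to a change at that position, and it says that the position is not indifferent.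

The unmeasured compound 3, `O=C(O)CCC/C=C\C[C@H]1[C@@H]2CCC(C2)[C@@H]1NS(=O)(=O)c1ccc(Cl)cc1`, differs from compound 1 as follows: 4-chlorophenyl in place of 2-methylphenyl on a sulfonyl sulfur. Both groups are single six-membered aromatic rings on the sulfonyl sulfur; the step from compound 1 to compound 2 bears on the position only, not on this kind of exchange. For the measured compounds named here, no measured pair shows a ring-for-ring exchange, so no direction can be read from the data. The step from compound 1 to compound 3 is therefore expected to stay near the scatter, a 1.0-fold lower number from compound 1 to compound 3 (0.01 log units; within the scatter). For compound 3 in this assay the estimate is 6000 nM, within 2500 nM to 15000 nM.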

Compound 3, half-maximal inhibitory concentration: 300 nM
Compound 3: the middle estimate sits 20-fold (1.30 log units) above what was measured; the measured number lies below the stated range.
By their numbers in this assay, from the lowest: compound 3; then compound 1; then compound 2.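

In this assay, the exchange of 2-methylphenyl for 4-chlorophenyl on the sulfonyl sulfur gives a 21-fold lower number from compound 1 to compound 3 (1.32 log units; beyond the scatter) as its step, which is larger than the step that replaced the ring with a chain (a 2.3-fold higher number from compound 1 to compound 2 (0.35 log units; beyond the scatter)). The position therefore responds strongly to which six-membered aromatic ring it carries, even though the two groups are counted alike in heavy atoms, hydrogen-bond donors and hydrogen-bond acceptors. Compared with 3-phenylpropyl, 4-chlorophenyl gives a 47-fold lower number from compound 2 to compound 3 (1.67 log units; beyond the scatter) as its step, the largest of the three, so an aromatic ring on the sulfonyl sulfur is not enough to place compound 1 near compound 3, and no supporting measurement bears on the size of these steps.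

The exchange changes both the substituent and its place on the ring, so the shift cannot yet be assigned to the chlorine or to its place; plain phenyl, 4-methylphenyl and 2-chlorophenyl on the same core would separate the two. Also open, as far as these compounds go, is whether 4-bromophenyl or 4-fluorophenyl would hold the low number of compound 3, and whether 3-phenylpropyl would respond to a chlorine on its ring in the same way.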